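Trading a ring substituent for dimethylamino

The compounds below may be only part of what the source reports. "The series", "measured", "known", "first", "only" and "open" are said of these compounds alone.

In an ADME assay on microsomes from liver (Homo sapiens) for metabolic stability, with a stated time of 60 min, tested at 1 uM (on this read-out higher numbers stand for a more stable compound and lower numbers for a less stable compound), three compounds sharing one core have been measured. Compound 1 `COc1cc(-c2cnn3cc(OC)c(C4CCOC4)nc23)ccn1`, which carries oxolan-3-yl, gives 29%. Compound 2 `COc1cc(-c2cnn3cc(OC)c(C)nc23)ccn1`, which carries methyl in its place, gives 44%. Compound 3 `COc1cc(-c2cnn3cc(OC)c([C@@H]4COC(C)(C)C4)nc23)ccn1` gives 13%, the lowest of the three numbers and beyond the scatter from both others.

Compound 4 `COc1cc(-c2cnn3cc(OC)c(N(C)C)nc23)ccn1` has not yet been measured. Its structural difference from compound 3 is a group of 3 heavy atoms (2 carbon, 1 nitrogen; no ring) in place of a group of 7 heavy atoms (6 carbon, 1 oxygen; one five-membered non-aromatic ring with 1 hetero atom), on an aromatic carbon.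

Among the measured compounds shown here, two measured steps bear most directly on this change, since each alters the group on that aromatic carbon: a number 31 percentage points lower from compound 2 to compound 3 (beyond the scatter) is large, and a number 16 percentage points lower from compound 1 to compound 3 (beyond the scatter) is modest. A third, a number 15 percentage points higher from compound 1 to compound 2 (beyond the scatter), is also modest. Across these three compounds the number is higher where the group is smaller, and none of them goes against this. For the measured compounds named here, no measured compound has dimethylamino there, so this guide is indirect. Dimethylamino is larger than the methyl of compound 2 at 44% and smaller than the oxolan-3-yl of compound 1 at 29%. A rise of modest to large size is therefore expected, estimated as a number 22 percentage points higher from compound 3 to compound 4 (beyond the scatter). For compound 4 the estimate is 35%, with an expected range from 18% to 55%.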

Compound 4, percent of the compound remaining: 16%
Compound 4: middle estimate off by 19 percentage points, on the high side, outside the stated range (below it).
By their numbers in this assay, from the lowest: compounds 3 and 4 (each within the scatter of the next); then compound 1; then compound 2.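

In this assay this position does not follow group size alone: dimethylamino, with 3 heavy atoms, in place of the group of 7 heavy atoms gives a number 3 percentage points higher from compound 3 to compound 4 (within the scatter), so the two groups cannot be told apart on this read-out. The other two new steps are a number 13 percentage points lower from compound 1 to compound 4 (beyond the scatter) and a number 28 percentage points lower from compound 2 to compound 4 (beyond the scatter); compound 4 therefore goes against the earlier pattern in which the number was higher where the group was smaller, while compound 2, with methyl, remains the highest of the four. No measurement here accounts for these numbers.

The compounds shown leave open whether the outcome for compound 4 belongs to any nitrogen attached at this aromatic carbon or only to dimethylamino, a question that a cyclic amine such as morpholine or a simple amino group could address. They also leave open where an ethyl group, a short chain only slightly larger than the methyl of compound 2, would fall on this read-out.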